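The compounds below may be only part of what the source reports. "The series", "measured", "known", "first", "only" and "open" are said of these compounds alone.

Measured in a physicochemical assay for solubility, using the shake flask method, measured as kinetic solubility, with a stated time of 2 h, at pH 7.4; on this read-out lower numbers stand for lower solubility and higher numbers for higher solubility:

- Compound 1 `CN(c1ccccc1)c1cc(C(=O)Nc2ccccc2)ncn1`: < 5000 nM, a limit
- Compound 2 `CN(Cc1ccc(Cl)cc1)c1cc(C(=O)Nc2ccccc2)ncn1`: < 5000 nM, a limit

Compound 2 has no exact number, only the limit < 5000 nM. Compound 3 `CN(Cc1cccc(Cl)c1)c1cc(C(=O)Nc2ccccc2)ncn1` differs from it by one change: 3-chlorophenyl in place of 4-chlorophenyl on a saturated chain carbon bound to a nitrogen on an aromatic ring, with 3-chlorophenyl in place of 4-chlorophenyl on a saturated chain carbon bound to a nitrogen on an aromatic ring. Going by the values given here, the only measured step is a step that the two limits leave unreadable from compound 1 to compound 2, and it gives no size to build on, as both compounds sit at the limit of < 5000 nM in this assay, at which 2 of the 2 values shown sit. No step beyond the scatter is therefore expected in this assay, and the estimated step is a step that the limit leaves unreadable from compound 2 to compound 3. For compound 3 the expected value is 3000 nM, with an estimated range of 1000 nM to 6000 nM.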

Compound 3, solubility: < 5000 nM
Compound 3 ended at the assay's limit (the forecaster's own chance of this, stated with the estimate: 90%); the middle value does not contradict the limit.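

No step between compound 1, compound 2 and compound 3 can be read in this assay, as each result is a limit and not a number: the limit of < 5000 nM in this assay, at which 3 of the 3 values shown sit.

As far as these compounds go, whether 4-chlorobenzyl and 3-chlorobenzyl give different solubilities remains open.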